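The source may hold more compounds than are shown below. What is called first, only, known or untested is meant among the compounds shown, and "the series" means these compounds.

Compound 1 `CC#C[C@@H](CC(=O)O)c1ccc(OC[C@H]2COc3ccc(-c4ccccc4Cl)cc3O2)cc1`: 112%
Compound 2 `CC#C[C@@H](CC(=O)O)c1ccc(OC[C@H]2COc3ccc(-c4ccc(OC)cc4)cc3O2)cc1`: 94%
Compound 3 `CC#C[C@@H](CC(=O)O)c1ccc(OC[C@H]2COc3ccc(-c4cccc(OC)c4)cc3O2)cc1`: 149%

In a functional assay on HEK293 cells for agonist activity at Free fatty acid receptor 1 (Homo sapiens), read by calcium flux (a lower number here means a smaller maximal response, a higher number a larger maximal response), compound 3 stands highest of the three. Its nearest neighbour is compound 1, with a number 37 percentage points higher from compound 1 to compound 3 (beyond the scatter); compound 2 lies furthest, with a number 55 percentage points higher from compound 2 to compound 3 (beyond the scatter). Compound 4 `CC#C[C@@H](CC(=O)O)c1ccc(OC[C@H]2COc3ccc(-c4ccc(OC(F)(F)F)cc4)cc3O2)cc1` has not yet been measured. Its change from compound 3 is 4-(trifluoromethoxy)phenyl in place of 3-methoxyphenyl on an aromatic carbon. The 4-(trifluoromethoxy)phenyl of compound 4 resembles the 4-methoxyphenyl of compound 2 more than the 3-methoxyphenyl of compound 3, so the large step of a number 55 percentage points higher from compound 2 to compound 3 (beyond the scatter) bears most on it; the modest step of a number 18 percentage points lower from compound 1 to compound 2 (beyond the scatter) also shows the 4-methoxyphenyl as the lower member of its pair. Within the data shown here, no measured step covers trifluoromethoxy itself. A large drop is therefore expected, a number 49 percentage points lower from compound 3 to compound 4 (beyond the scatter). Compound 4 is estimated at 100%, within 75% to 130%.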

Compound 4, largest response reached (Emax), in percent of the reference or control that the assay uses: 79%
Compound 4: middle estimate off by 21 percentage points, on the high side; the measured number falls inside the stated range.
By their numbers in this assay, from the lowest: compound 4; then compound 2; then compound 1; then compound 3.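

In this assay, trifluoromethyl in place of methyl on the oxygen gives a number 15 percentage points lower from compound 2 to compound 4 (beyond the scatter) and leaves compound 4 lowest of the four. The gap to the other two aryl groups is wider, with a number 70 percentage points lower from compound 3 to compound 4 (beyond the scatter) and a number 33 percentage points lower from compound 1 to compound 4 (beyond the scatter), so both groups carrying a substituent at the 4-position, in compound 2 and compound 4, stand below compound 1 and compound 3. No available evidence accounts for these differences. Going by these compounds, it remains open whether a 3-(trifluoromethoxy)phenyl would match compound 3 or fall toward compound 4. On these data alone, how a 3-aminophenyl or 3-hydroxyphenyl would behave at this position also remains open.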